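Cyclobutyl in place of the 2-oxooxetan-3-yl ring of compound 1

The source may hold more compounds than are shown below. What is called first, only, known or untested is meant among the compounds shown, and "the series" means these compounds.

Measured so far:
compound 1 `O=C(CCc1ccccc1)N[C@H]1COC1=O` — 420 nM
compound 2 `O=C(N[C@H]1COC1=O)c1ccc(OCc2ccccc2)cc1` — 90 nM
compound 3 `O=C(CCc1ccccc1)N[C@@H](CO)C(=O)O` — > 100000 nM

In an assay on HEK293 cells for inhibition of N-acylethanolamine-hydrolyzing acid amidase (Rattus norvegicus), with a stated time of 30 min (a higher number here means a weaker inhibitor, a lower number a stronger inhibitor), compound 1 gives 420 nM and stands as the weaker of the two numerical values, with compound 2 the nearer neighbour at a gap beyond the scatter. Compound 3 reaches only a limit, not a number: the limit of > 100000 nM in this assay, at which 1 of the 3 values shown sits.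

The next step, from compound 1 to compound 4 `O=C(CCc1ccccc1)NC1CCC1`, is cyclobutyl in place of 2-oxooxetan-3-yl on an amide-type nitrogen. Within the data shown here, no measured pair shows this change, so the expectation rests on what the three values show: both numerical values belong to compounds that carry the 2-oxooxetan-3-yl ring, while the one compound without it, compound 3, reports only a limit. On that basis a large loss in this assay is expected for compound 4, and it is more likely than not that only a limit will again be reported. The estimate for compound 4 is 150000 nM, within 20000 nM to 1000000 nM, which would mean an expected step of a 360-fold higher number from compound 1 to compound 4 (2.55 log units; beyond the scatter).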

Compound 4, half-maximal inhibitory concentration: > 100000 nM
Compound 4 ended at the assay's limit; the forecaster's own chance of this, stated with the estimate: 75%; the middle value lies beyond the limit too.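

In this assay, cyclobutyl in place of 2-oxooxetan-3-yl on the amide-type nitrogen gives an at least 230-fold higher number from compound 1 to compound 4 (2.37 log units; beyond the scatter). Among these compounds, this is the first direct reading of this position: a four-membered ring stays, but its two oxygens and its double bond leave, and the rest of compound 1 is unchanged, so a four-membered ring alone does not keep a numerical value here. Compound 4 gives only a limit, not a number: the limit of > 100000 nM in this assay, at which 2 of the 4 values shown sit.

The true size of the step stays open, and the compounds shown do not separate the contribution of the ring oxygen from that of the carbonyl, a question that an open-chain ester or a ketone at this position could address. Also open, from the compounds shown here alone, is whether cyclobutyl has the same effect on the acyl side of compound 2.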